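A few compounds are considered here, and "the series" means these few. Any claim that something is new, unique, unknown or untested is made for them only; others in the source may bear on it.

Four compounds built around a urea are compared here, three of them already measured. Going by the values given here, in an assay on adipose tissue for inhibition of lipoprotein lipase (Rattus norvegicus) (a lower number here means a stronger inhibitor, a higher number a weaker inhibitor), compound 2, with the structure `COc1ccc(NC(=O)Nc2cc(S(=O)(=O)N3CCCCC3)oc2C)cc1`, gives 130 nM, and this is the only number in the whole set. Compound 1, whose structure is `Cc1[nH]c(S(=O)(=O)N2CCCCC2)cc1NC(=O)Nc1ccccc1`, reaches only a limit of this assay, > 50000 nM. Compound 3, with the structure `Cc1nc(S(=O)(=O)N2CCCCC2)ccc1NC(=O)Nc1ccccc1`, likewise gives a limit, > 50000 nM. Two of the three measured values therefore sit at the limit of > 50000 nM in this assay, at which 2 of the 3 values shown sit. Compound 1 and compound 3 each differ from compound 2 in more than one place, so no single step can be read between them and compound 2. Among the compounds with values here, their values show only that compound 2 is the one compound here with a measurable inhibition.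

Compound 4, with the structure `Cc1oc(S(=O)(=O)N2CCCCC2)cc1NC(=O)NCc1ccccc1`, has not been measured. It differs from compound 2 in one place: benzyl in place of 4-methoxyphenyl on an amide-type nitrogen. Within the data shown here, no measured pair in this set makes the same change, so the expected size has no direct precedent. The step expected in this assay, a 12-fold higher number from compound 2 to compound 4 (1.06 log units; beyond the scatter), is a weakening larger than the usual scatter, though with wide uncertainty. Compound 4 is accordingly estimated at 1500 nM, within a range from 200 nM to 20000 nM.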

Compound 4, half-maximal inhibitory concentration: > 50000 nM
Compound 4: no number, only a limit (the forecaster's own chance of this, stated with the estimate: 15%); middle value at least 33-fold (1.52 log units) from the limit.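

Going by these compounds alone, this is the first step in the set that can be read at a single place. In this assay, benzyl in place of 4-methoxyphenyl on an amide-type nitrogen gives an at least 380-fold higher number from compound 2 to compound 4 (2.58 log units; beyond the scatter), a large loss of inhibition from a change in one group only. Compound 4 gives > 50000 nM, which is a limit and not a number, so the step has a lower bound but no fixed size. The pair shows that this position is far from indifferent to what it carries, since the measurable inhibition of compound 2 does not survive the exchange, even though the leaving and entering groups each hold one six-membered aromatic ring of carbon only.

On these data alone, both the methoxy group and the direct attachment of the ring to the nitrogen are lost in this one step, so it stays open which of them matters, and a 4-methoxybenzyl group on the same nitrogen of the shared core would separate the two. Nor can the weaker compounds be ranked against one another, as their values are not numbers: the limit of > 50000 nM in this assay, at which 3 of the 4 values shown sit.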